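From methylamino to piperidin-1-yl on the sulfonyl sulfur

A few compounds are considered here, and "the series" means these few. Any claim that something is new, unique, unknown or untested is made for them only; others in the source may bear on it.

In an ADME assay on microsomes from liver (Mus musculus) for metabolic stability, tested at 5 uM (on this read-out higher numbers stand for a longer-lived compound and lower numbers for a shorter-lived compound), compound 1 (`CCCCCCNc1ccc(C(=O)O)cc1S(=O)(=O)NC`) gives 0.483 h. Compound 2 (`CNS(=O)(=O)c1cc(C(=O)O)ccc1NCCCCCCCC(F)(F)F`) stands at > 1 h, which is a limit of the assay and not a number. Within the data shown here, the only measured step is an at least 2.0-fold higher number from compound 1 to compound 2 (0.31 log units; beyond the scatter), and it comes with 2,2,2-trifluoroethyl in place of hydrogen on a saturated chain carbon.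

Compound 3 (`O=C(O)c1ccc(NCCCCCCCC(F)(F)F)c(S(=O)(=O)N2CCCCC2)c1`) keeps that chain and carries piperidin-1-yl in place of methylamino on a sulfonyl sulfur. Among the measured compounds shown here, no step at the sulfonyl sulfur has been measured in this assay. The step on the chain therefore bears on this change only loosely, as a guide to size: an at least 2.0-fold higher number from compound 1 to compound 2 (0.31 log units; beyond the scatter). A step of no greater size is expected, with a slight lean towards a shorter half-life, and it may stay within the scatter. The expected step, estimated against a limit rather than a number, is an at least 1.2-fold lower number from compound 2 to compound 3 (0.09 log units; that floor lies within the scatter). For compound 3 the estimated half-life is 0.8 h, with an expected range of 0.35 h to 1.6 h.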

Compound 3, half-life: > 1 h
Compound 3 ended at the assay's limit; the forecaster's own chance of this, stated with the estimate: 35%; middle value at least 1.2-fold (0.09 log units) from the limit.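

In this assay compound 2 and compound 3 both sit at a limit of the assay and not at a number, so no step can be read between them: the limit of > 1 h in this assay, at which 2 of the 3 values shown sit. On these data alone, whether piperidin-1-yl in place of methylamino on a sulfonyl sulfur lengthens or shortens the half-life stays open, as does how far past the limit either compound lies.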